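Propyl to isopropyl on the ether side chain

A few compounds are considered here, and "the series" means these few. Any claim that something is new, unique, unknown or untested is made for them only; others in the source may bear on it.

In a functional assay on MES-SA cells (Homo sapiens) for inhibition, with a stated time of 72 h, in the presence of a further agent that is not named here (a lower number here means a stronger inhibitor, a higher number a weaker inhibitor), compound 1 `Oc1c(CN2CCCCC2)ccc2cccnc12` gives 4180 nM; 4070 nM (2 entries), two entries in close agreement. Compound 2 `CCCOCc1cc(CN2CCCCC2)c(O)c2ncccc12` has one number, 3550 nM, which lies within the scatter of compound 1. Compound 3 `CC(C)OCc1cc(CN2CCCCC2)c(O)c2ncccc12` differs from compound 2 as follows: isopropyl in place of propyl on an oxygen on a saturated carbon. It has isopropyl in place of propyl on an oxygen on a saturated carbon. Among the measured compounds shown here, no measured step covers this change, so no shift beyond the scatter is expected in this assay, in either direction. The expected 1.0-fold lower number from compound 2 to compound 3 (0.01 log units; within the scatter) is small. For compound 3 the estimated value is 3500 nM, with an expected range of 1900 nM to 6500 nM.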

Compound 3, half-maximal inhibitory concentration: 5750 nM
Compound 3: the middle estimate sits 1.6-fold (0.22 log units) below what was measured; the measured number falls inside the stated range.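

In this assay, among the compounds shown here, exchanging propoxymethyl for isopropoxymethyl gives a 1.6-fold higher number from compound 2 to compound 3 (0.21 log units; within the scatter), the only measured step on this ether side chain. On the oxygen, propyl and isopropyl therefore cannot be told apart in this assay. Agreement between repeat entries is shown only for compound 1: the several entries of compound 1 in this assay, 4180 nM; 4070 nM (2 entries)

Still open, from the compounds shown here alone, is whether a longer chain such as hexyl on the oxygen, or a terminal amine on that chain, would move the number beyond the scatter. Going by these compounds, whether the piperidine-bearing side of the core would respond to a change also remains open.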